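A few compounds are considered here, and "the series" means these few. Any claim that something is new, unique, unknown or untested is made for them only; others in the source may bear on it.

Working notes on the series.

Compound 1 `C=CC(C)(C)c1[nH]c2ccccc2c1/C=C1\NC(=O)[C@H](C)NC1=O` is one of three measured members. In an ADME assay on MDCK cells (Canis lupus familiaris) for cytotoxicity, read by CellTiter-Glo, with a stated time of 40 h (a higher number here means that more compound is tolerated, a lower number that less compound is tolerated), compound 1 gives > 200000 nM, which is a limit of this assay and not a number. Compound 2 `C=CC(C)(C)c1[nH]c2ccccc2c1/C=c1\[nH]c(=O)c(=C)[nH]c1=O` shares part of its build with compound 1; the difference between the two cores is not broken down here. In this assay compound 2 gives > 200000 nM, again a limit rather than a number. Compound 3 `C=CC(C)(C)c1[nH]c2c(CC=C(C)C)cccc2c1/C=c1\[nH]c(=O)c(=C)[nH]c1=O` carries 3-methylbut-2-en-1-yl in place of hydrogen on an aromatic carbon. In this assay compound 3 gives > 200000 nM, also a limit. The step that the two limits leave unreadable from compound 2 to compound 3 therefore cannot be sized, since the limit of > 200000 nM in this assay, at which 3 of the 3 values shown sit, sets both ends.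

Compound 4 `C=CC(C)(C)c1[nH]c2ccc(CC=C(C)C)cc2c1/C=C1\NC(=O)[C@H](C)NC1=O` is not yet measured. Relative to compound 1 it carries 3-methylbut-2-en-1-yl in place of hydrogen on an aromatic carbon. This is the same kind of change as that from compound 2 to compound 3, though not the same: in compound 3 the group sits ortho to a fused ring and meta to a fused ring, whereas in compound 4 it sits meta to a fused ring and para to a fused ring.

The step expected from compound 1 to compound 4 in this assay is a step that the limit leaves unreadable from compound 1 to compound 4, resting on the limits of compound 1 > 200000 nM and on the fact that the limit of > 200000 nM in this assay, at which 3 of the 3 values shown sit, is where every measured value of the series sits. For compound 4 the estimated value in this assay is 300000 nM, with an expected range from 150000 nM to 1000000 nM, and most likely the readout will again be a limit.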

Compound 4, half-maximal cytotoxic concentration: > 200000 nM
Compound 4: only a limit was reported (the forecaster's own chance of this, stated with the estimate: 85%); the middle value is on the limit's open side.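

No step can be read from compound 1 to compound 4 in this assay, because both compounds sit at the same assay limit: the limit of > 200000 nM in this assay, at which 4 of the 4 values shown sit.

The compounds shown leave open where the half-maximal cytotoxic concentration of any of them lies, and whether 3-methylbut-2-en-1-yl in place of hydrogen on an aromatic carbon shifts it at all, in compound 3 or in compound 4.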